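The compounds below may be only part of what the source reports. "The series", "measured", "known", "first", "only" and "open" are said of these compounds alone.

Measured compounds:
- Compound 1, `CCCCCCCCCCCCCCCCCCNC(=O)[C@@H](NC(=O)c1cccs1)[C@@H](C)O`: 33300 nM
- Compound 2, `C/C=C/C=C/C(=O)N[C@H](C(=O)NCCCCCCCCCCCCCCCCCC)[C@@H](C)O`: 187000 nM

Among the measured compounds shown here, in a functional assay on A-431 cells (Homo sapiens) for cytotoxicity, read by MTT assay, with a stated time of 48 h (a higher number here means a weaker inhibitor, a lower number a stronger inhibitor), compound 2 stands with the higher of the two numbers recorded; the only other compound, compound 1, gives 33300 nM in this assay, and the single measured step, a 5.6-fold higher number from compound 1 to compound 2 (0.75 log units; beyond the scatter), ran from the thiophen-2-yl carbonyl of compound 1 to the penta-1,3-dien-1-yl carbonyl of compound 2.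

Compound 3, `CCCCCCCCCCCCCCCCCCNC(=O)[C@@H](NS(=O)(=O)c1cccs1)[C@@H](C)O`, is not yet measured. It differs from compound 2 in one place: (thiophen-2-yl)sulfonyl in place of (penta-1,3-dien-1-yl)carbonyl on an amine nitrogen. This change returns the thiophen-2-yl ring that compound 1 carries, but joins it to the nitrogen through a sulfonyl rather than a carbonyl. For the measured compounds named here, the step of a 5.6-fold higher number from compound 1 to compound 2 (0.75 log units; beyond the scatter) therefore bears on it in reverse, suggesting that bringing the ring back should lower the number; for the carbonyl-to-sulfonyl part of the change no measured step exists, and its effect is unknown.

On that basis compound 3 is expected to return toward the value of compound 1, giving an estimated 4.2-fold lower number from compound 2 to compound 3 (0.62 log units; beyond the scatter), with an estimate of 45000 nM for compound 3 and a range from 10000 nM to 180000 nM.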

Compound 3, half-maximal inhibitory concentration: > 200000 nM
Compound 3: a limit, no number; the forecaster's own chance of this, stated with the estimate: 15%; middle value at least 4.4-fold (0.64 log units) away from the limit.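

In this assay the reading for compound 3 is a limit and not a number: the limit of > 200000 nM in this assay, at which 1 of the 3 values shown sits. With the thiophen-2-yl ring kept and only its link to the amine nitrogen changed from carbonyl to sulfonyl, the shift is an at least 6.0-fold higher number from compound 1 to compound 3 (0.77 log units; beyond the scatter), so the ring alone does not carry the lower number of compound 1, and the link on this nitrogen matters as much as the group it bears, which the earlier pair could not show. Against the dienyl compound the reading gives only a floor, an at least 1.0-fold higher number from compound 2 to compound 3 (0.02 log units; that floor lies within the scatter), so compound 3 cannot be separated from compound 2 on these data, and a thiophen-2-yl ring on this nitrogen gives no lower number once it is joined through a sulfonyl.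

As far as these compounds go, how far the true value of compound 3 lies past its limit stays open, as does whether the sulfonyl link would have the same effect with the penta-1,3-dien-1-yl group in place of the ring. Also open, from the compounds shown here alone, is how a phenyl ring or a simple acetyl group on this amine nitrogen would read, and whether a shorter chain in place of the long saturated one would shift these numbers.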